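From ethoxy to propoxy: compound 3 to compound 4

The source may hold more compounds than are shown below. What is called first, only, known or untested is meant among the compounds shown, and "the series" means these compounds.

Values in a physicochemical assay for lipophilicity, using the shake flask method, in phosphate buffer, measured as octanol-water partition, with a stated time of 24 h, at pH 7.4, tested at 100 uM (a lower number here means a more polar compound, a higher number a more lipophilic compound), for the measured compounds
Compound 1 `Cc1cccc(C)c1-c1cccc(COc2ccc(S(=O)(=O)CC(=O)O)cc2)c1` gives 2.49
Compound 2 `COc1cc(C)c(-c2cccc(COc3ccc(S(=O)(=O)CC(=O)O)cc3)c2)c(C)c1` gives 2.45
Compound 3 `CCOc1cc(C)c(-c2cccc(COc3ccc(S(=O)(=O)CC(=O)O)cc3)c2)c(C)c1` gives 2.86

Compound 3 stands highest of the three at 2.86 and lies beyond the scatter from both others. The next compound is compound 4 `CCCOc1cc(C)c(-c2cccc(COc3ccc(S(=O)(=O)CC(=O)O)cc3)c2)c(C)c1` and the change is methyl in place of hydrogen on a saturated chain carbon, two bonds along the chain from an oxygen on an aromatic ring in which ethoxy becomes propoxy. The closest measured case is a number 0.41 log units higher from compound 2 to compound 3 (beyond the scatter) with methyl in place of hydrogen on a saturated chain carbon bound to an oxygen on an aromatic ring. A similar size appears in a number 0.37 log units higher from compound 1 to compound 3 (beyond the scatter) for ethoxy in place of hydrogen on an aromatic carbon. The series does not rise evenly, however, as a number 0.04 log units lower from compound 1 to compound 2 (within the scatter) for methoxy in place of hydrogen on an aromatic carbon shows. In this assay a modest rise beyond the scatter is expected, resting mainly on the single closest case. For the measured compounds named here, the expected step is a number 0.39 log units higher from compound 3 to compound 4 (beyond the scatter) and only that one precedent supports its size. For compound 4 the estimated value is 3.25 with an expected range from 2.95 to 3.55 on present data.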

Compound 4, distribution coefficient: 3.58
Estimate against measurement, compound 4: 0.33 log units below, and the stated range ends below it.
By their numbers in this assay, from the lowest: compounds 2 and 1 (each within the scatter of the next); then compound 3; then compound 4.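

In this assay the step from ethoxy to propoxy is a number 0.72 log units higher from compound 3 to compound 4 (beyond the scatter) and exceeds the step for the same methyl in place of hydrogen on the saturated chain carbon bound to an oxygen on an aromatic ring, which is a number 0.41 log units higher from compound 2 to compound 3 (beyond the scatter), so the two added methyl groups do not give equal steps in this short series. Measured against the shorter groups, the propoxy group gives a number 1.13 log units higher from compound 2 to compound 4 (beyond the scatter) and a number 1.09 log units higher from compound 1 to compound 4 (beyond the scatter), which places compound 4 highest of the four, beyond the scatter of each of the others. No available evidence bears on why the second methyl gives the larger step.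

On these data alone, whether the numbers keep rising with a longer chain such as butoxy remains open, since two steps along one chain fix no trend. Equally open, as far as these compounds go, is how the number would move if the propoxy chain carried an amine or a hydroxyl group.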